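This account rests on a few compounds, and the source may have more. Where it says the series, first, only, none or still open, it means among the compounds named here.

Measured so far:
compound 1 `O=C(CCCCCCC(=O)Nc1nc2ccccc2s1)NO` — 6.61 ug/mL
compound 2 `O=C(CCCCC(=O)Nc1nc2ccc([N+](=O)[O-])cc2s1)NO` — > 30 ug/mL

For the measured compounds named here, in a functional assay on MCF7 cells (Homo sapiens) for cytotoxicity (on this read-out lower numbers stand for stronger inhibition and higher numbers for weaker inhibition), compound 1 gives 6.61 ug/mL, the only actual number among the two results. Compound 2 gives only a limit of the assay, > 30 ug/mL; this is the limit of > 30 ug/mL in this assay, at which 1 of the 2 values shown sits. Compound 3 `COc1ccc2nc(NC(=O)CCCCCCC(=O)NO)sc2c1` differs from compound 1 in one place: methoxy in place of hydrogen on an aromatic carbon. Going by the values given here, no two measured compounds differ in just one place, so no measured step guides this change; in this assay a step no larger than the usual scatter, in either direction, is expected. Compound 3 is therefore estimated at 6.5 ug/mL, from 3 ug/mL to 14 ug/mL, a step of a 1.0-fold lower number from compound 1 to compound 3 (0.01 log units; within the scatter).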

Compound 3, half-maximal inhibitory concentration: 1.85 ug/mL
Estimate against measurement, compound 3: 3.5-fold (0.55 log units) above; measured number outside the range, below it.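

In this assay methoxy in place of hydrogen on this aromatic carbon gives a 3.6-fold lower number from compound 1 to compound 3 (0.55 log units; beyond the scatter) and so moves the number by more than the usual scatter. For the compounds shown here, this is the first step between two measured compounds that differ in one place, and it shows that this carbon of the shared core can carry a group other than hydrogen without loss of inhibition. Nothing shown here gives a reason for this gain. From the compounds shown here alone, whether fluorine or an amine on this same carbon would lower the number as well remains open. So does whether methoxy would give a similar step on a longer chain.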